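A few compounds are considered here, and "the series" means these few. Any claim that something is new, unique, unknown or untested is made for them only; others in the source may bear on it.

Measured so far, in a functional assay for agonist activity at Free fatty acid receptor 1 (Homo sapiens), read by FLIPR, in the presence of a further agent that is not named here; a lower number here means that less compound is needed, a higher number that more compound is needed for the effect:

compound 1, `Cc1ccc(C)c(Oc2ccc(CC3SC(=O)NC3=O)cc2)c1`, gives 238 nM
compound 2, `Cc1ccccc1Oc1ccc(CC2SC(=O)NC2=O)cc1`, gives 124 nM
compound 3, `O=C1NC(=O)C(Cc2ccc(Oc3cc(C(F)(F)F)ccn3)cc2)S1`, gives 237 nM

Compounds 1 and 2 share one core; compound 3 has another, and the difference between the two cores is not broken down here. Between compound 2 and compound 1 the change is methyl in place of hydrogen on an aromatic carbon, and it gave a 1.9-fold higher number from compound 2 to compound 1 (0.28 log units; within the scatter). Compound 3 stands close to compound 1 in this assay, and the gap to compound 2 is also within the scatter, so the three numbers are not ordered by these data.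

Compound 4, `Cc1cc(C(F)(F)F)cc(Oc2ccc(CC3SC(=O)NC3=O)cc2)n1`, is not yet measured. It differs from compound 3 by methyl in place of hydrogen on an aromatic carbon. This is the same kind of change as from compound 2 to compound 1, but not the same: there the place was on a six-membered aromatic ring of carbon only, para to a methyl group; here it is on a ring with 1 nitrogen, next to the ring nitrogen and meta to a trifluoromethyl group. Among the measured compounds shown here, only one earlier instance exists, so the expectation rests on that step alone and on the value of compound 3, 237 nM. For compound 4 in this assay the step expected is a 1.5-fold higher number from compound 3 to compound 4 (0.17 log units; within the scatter), a small shift as seen from compound 2 to compound 1. The estimate for compound 4 is therefore 350 nM, with a range from 120 nM to 1000 nM.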

Compound 4, half-maximal effective concentration: 218 nM
Estimate against measurement, compound 4: 1.6-fold (0.21 log units) above; the measured number falls inside the stated range.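

In this assay, methyl in place of hydrogen on an aromatic carbon of the ring with 1 nitrogen gives a 1.1-fold lower number from compound 3 to compound 4 (0.04 log units; within the scatter). Set beside the earlier instance of the change, the two steps cannot be told apart: the same change on two cores in this assay, a 1.9-fold higher number (0.28 log units; within the scatter) from compound 2 to compound 1 and a 1.1-fold lower number (0.04 log units; within the scatter) from compound 3 to compound 4, 2.1-fold (0.32 log units) apart, within the scatter of two such steps The change has therefore been carried across two cores with neither step beyond the scatter, but this does not fix a size or direction for it on either core, and two instances do not show that it will behave alike on a further core.

The compounds shown leave open what a group other than methyl would do at this place, such as a longer chain, an amine or a carboxylic acid. Also open, going by these compounds, is whether the step on the core of compound 3 depends on the trifluoromethyl group, which a nitrile or a plain hydrogen in its place could test.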